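Adding one carbon to the amide chain of compound 3

The compounds below may be only part of what the source reports. "The series", "measured", "known", "first", "only" and "open" are said of these compounds alone.

Compound 1 `COc1cccc(CNC(C)=O)c1` gives 57000 nM in an assay for binding affinity to melatonin receptor (Gallus gallus); on this read-out lower numbers stand for stronger inhibition and higher numbers for weaker inhibition. Compound 2 `CCC(=O)NCc1cccc(OC)c1` gives 22000 nM in this assay. The change between them, (methyl in place of hydrogen on a saturated chain carbon bound to a carbonyl carbon), produced a 2.6-fold lower number from compound 1 to compound 2 (0.41 log units; beyond the scatter). Compound 3 `CCC(=O)NCCCc1ccccc1OC` gives 374 nM in this assay, the lowest of the three numbers, well beyond the scatter from both others; the difference between its core and the core of compound 1 is not broken down here. Compound 4 `CCCC(=O)NCCCc1ccccc1OC` has not yet been measured in this assay. It differs from compound 3 by methyl in place of hydrogen on a saturated chain carbon, two bonds along the chain from a carbonyl carbon. Among the measured compounds shown here, this is the same kind of change as the one from compound 1 to compound 2, not the same: there the methyl enters on a saturated chain carbon bound to a carbonyl carbon, here on a saturated chain carbon two bonds along the chain from a carbonyl carbon. For the measured compounds named here, the expected step is a 1.5-fold lower number from compound 3 to compound 4 (0.17 log units; within the scatter), kept smaller than the earlier one because a 2.6-fold lower number from compound 1 to compound 2 (0.41 log units; beyond the scatter) is the only instance available and it sits one bond closer to the carbonyl. For compound 4 the estimate is 250 nM, with a likely range from 100 nM to 600 nM.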

Compound 4, inhibition constant: 442 nM
Compound 4: the middle estimate sits 1.8-fold (0.25 log units) below what was measured, within the range that was stated.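

The methyl on the amide chain gives a 1.2-fold higher number from compound 3 to compound 4 (0.07 log units; within the scatter), so in this assay this step shows no change that can be told from the scatter on this core. Set beside the earlier step, the change does not carry over at the same size from one core to the other: the same change on two cores in this assay, a 2.6-fold lower number (0.41 log units; beyond the scatter) from compound 1 to compound 2 and a 1.2-fold higher number (0.07 log units; within the scatter) from compound 3 to compound 4, 3.1-fold (0.49 log units) apart, beyond the scatter of two such steps. This does not show why the two steps part, as the cores differ and the methyl also enters at different places, on a saturated chain carbon bound to a carbonyl carbon in one pair and two bonds along the chain from a carbonyl carbon in the other, and single pairs cannot separate these two differences.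

The compounds shown leave open what the methyl does two bonds along the chain from a carbonyl carbon on the core of compound 1. They also leave open whether a longer chain or an amine on the amide chain of compound 4 would move the number beyond the scatter.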